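Sulfoxide in place of benzylsulfanyl on the shared core

The compounds below may be only part of what the source reports. "The series", "measured", "known", "first", "only" and "open" are said of these compounds alone.

Measured so far:
compound 1 `CN1CCN(c2ccc(Nc3ncc4nc(SCc5ccccc5)n(C5CCOCC5)c4n3)cc2)CC1` gives 107 nM
compound 2 `CN(C)C1CCN(c2ccc(Nc3ncc4nc(Sc5ccccc5)n(C5CCOCC5)c4n3)cc2)CC1` gives 29.4 nM

In a functional assay on HCC827 cells (Homo sapiens) for antiproliferative activity, read by MTT assay, with a stated time of 72 h (a higher number here means a weaker inhibitor, a lower number a stronger inhibitor), compound 1 stands with the higher of the two numbers, and compound 2 gives the lower one, a gap beyond the scatter. Compound 3 `CN1CCN(c2ccc(Nc3ncc4nc([S+]([O-])c5ccccc5)n(C5CCOCC5)c4n3)cc2)CC1` is not yet measured. It differs from compound 1 by a group of 8 heavy atoms (6 carbon, 1 oxygen, 1 sulfur; one six-membered aromatic ring of carbon only) in place of a group of 8 heavy atoms (7 carbon, 1 sulfur; one six-membered aromatic ring of carbon only), on an aromatic carbon. Among the measured compounds shown here, no step between measured compounds covers this change, so only a modest shift is expected, with no firm direction. For compound 3 the expected value is 80 nM with a range of 20 nM to 400 nM, and the step of a 1.3-fold lower number from compound 1 to compound 3 (0.13 log units; within the scatter) is estimated to lie close to the scatter.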

Compound 3, half-maximal inhibitory concentration: 411 nM
Compound 3: middle estimate off by 5.1-fold (0.71 log units), on the low side; measured number outside the range, above it.
By their numbers in this assay, from the lowest: compound 2; then compound 1; then compound 3.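

Among the compounds shown here, the sulfoxide in place of benzylsulfanyl gives a 3.8-fold higher number from compound 1 to compound 3 (0.58 log units; beyond the scatter) in this assay and is the first single-place change read here. It shows that activity responds to the group on this aromatic carbon, between two ring nitrogen atoms, even when the heavy-atom count stays the same. No measurement shown accounts for the loss.

The change swaps one carbon for an oxygen and alters the sulfur in the same step, so the two cannot be told apart. The shown compounds also leave open how a sulfone or an amine would behave on this carbon.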